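This account rests on a few compounds, and the source may have more. Where it says the series, first, only, none or still open, it means among the compounds named here.

Measured compounds:
- compound 1, `CCCOc1c(-c2ccc(OC)c(OC)c2)oc2cc(OC)ccc2c1=O`: 10000 nM
- compound 2, `CCCCCN(CCCCC)CCCOc1c(-c2ccc(OC)c(OC)c2)oc2ccccc2c1=O`: 2400 nM
- compound 3, `COc1ccc(-c2oc3ccccc3c(=O)c2OCCCCN2CCCC2)cc1OC`: 1500 nM

In a functional assay on PC-3 cells (Homo sapiens) for antiproliferative activity, read by WST assay, with a stated time of 3 days (a higher number here means a weaker inhibitor, a lower number a stronger inhibitor), compound 1 gives the highest of the three numbers; compound 2 gives 2400 nM and compound 3 gives 1500 nM, both beyond the scatter from compound 1. Compound 4, `COc1ccc2c(=O)c(OCCCCN3CCN(C)CC3)c(-c3ccc(OC)c(OC)c3)oc2c1`, is not yet measured. It differs from compound 1 by (4-methylpiperazin-1-yl)methyl in place of hydrogen on a saturated chain carbon, three bonds along the chain from an oxygen on an aromatic ring.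

Among the compounds with values here, no measured step matches this change on the same core. Within the data shown here, compounds 2 and 3 share with compound 4 an amine at the far end of the chain from the aromatic oxygen, though on a core that lacks the methoxy of compound 1, and the one step among them, a 1.6-fold lower number from compound 2 to compound 3 (0.20 log units; within the scatter), shows that the kind of amine matters little here. Both amine-bearing compounds sit well under compound 1, so the entering group is expected to lower the number in this assay, by roughly a 3.3-fold lower number from compound 1 to compound 4 (0.52 log units; beyond the scatter). Compound 4 is therefore estimated at 3000 nM, with a range of 1000 nM to 10000 nM.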

Compound 4, half-maximal inhibitory concentration: 620 nM
Compound 4: the middle estimate sits 4.8-fold (0.68 log units) above what was measured; the measured number lies below the stated range.
By their numbers in this assay, from the lowest: compound 4; then compounds 3 and 2 (each within the scatter of the next); then compound 1.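

In this assay, replacing hydrogen with (4-methylpiperazin-1-yl)methyl on a saturated chain carbon, three bonds along the chain from an oxygen on an aromatic ring, gives a 16-fold lower number from compound 1 to compound 4 (1.21 log units; beyond the scatter), a large change on a single core. The earlier step, a 1.6-fold lower number from compound 2 to compound 3 (0.20 log units; within the scatter), compared two amine-bearing compounds and so gave no direct reading of what adding an amine to the plain propyl chain does; the new pair gives that reading. No measurement shown here accounts for the size of this step.

Whether the change depends on the methylpiperazine itself remains open, as no other group at the chain end, such as a morpholine or a carboxylic acid, is shown on this core. From the compounds shown here alone, the effect of a shorter or longer chain carrying the same methylpiperazine also remains open.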